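The source may hold more compounds than are shown below. What is called first, only, known or untested is meant among the compounds shown, and "the series" means these compounds.

Measured compounds in a functional assay on CHO-K1 cells for antagonist activity at transient receptor potential cation channel subfamily V member 1 (Homo sapiens), read by FLIPR; on this read-out higher numbers stand for weaker inhibition and lower numbers for stronger inhibition:
compound 1 `Cc1ccc(Cl)cc1Nc1nc(C(F)(F)F)ccc1CNC(=O)C(C)c1ccc(NS(C)(=O)=O)c(F)c1`, 140 nM
compound 2 `COC1CCN(c2nc(C(F)(F)F)ccc2CNC(=O)C(C)c2ccc(NS(C)(=O)=O)c(F)c2)CC1`, 280 nM

Compound 2 carries the highest of the two numbers obtained so far in this assay. Its nearest neighbour is compound 1, and the gap between the two lies within the scatter, so the pair is not separated on this read-out. For the measured compounds named here, the single measured step, a 2.0-fold higher number from compound 1 to compound 2 (0.30 log units; within the scatter), exchanges an aryl amino group for a saturated ring at an aromatic carbon of the shared core and stays within the scatter.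

Compound 3 `CC(C(=O)NCc1ccc(C(F)(F)F)nc1N1CCCCCCC1)c1ccc(NS(C)(=O)=O)c(F)c1` is not yet measured. Relative to compound 2 the change is a group of 8 heavy atoms (7 carbon, 1 nitrogen; one eight-membered non-aromatic ring with 1 hetero atom) in place of a group of 8 heavy atoms (6 carbon, 1 nitrogen, 1 oxygen; one six-membered non-aromatic ring with 1 hetero atom), on an aromatic carbon. The step from compound 1 to compound 2 is the only one that touches this part of the core; it shows that a substantial exchange at this carbon left the number within the scatter. The present change exchanges one saturated nitrogen-containing ring for another, so no step beyond the scatter is expected in this assay. Compound 3 is expected to stay close to its parent, a 1.1-fold higher number from compound 2 to compound 3 (0.03 log units; within the scatter). The estimate for compound 3 is 300 nM, with a range from 100 nM to 900 nM.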

Compound 3, half-maximal inhibitory concentration: 27.8 nM
Estimate against measurement, compound 3: 11-fold (1.03 log units) above, outside the stated range (below it).
By their numbers in this assay, from the lowest: compound 3; then compounds 1 and 2 (each within the scatter of the next).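

In this assay the aromatic carbon next to the ring nitrogen proves sensitive to the group it carries, which the pair of compound 1 and compound 2 did not reveal, since their step stayed within the scatter. The eight-membered ring moves the number beyond the scatter against both earlier groups, the saturated 4-methoxypiperidin-1-yl (a 10-fold lower number from compound 2 to compound 3 (1.00 log units; beyond the scatter)) and the (5-chloro-2-methylphenyl)amino group (a 5.0-fold lower number from compound 1 to compound 3 (0.70 log units; beyond the scatter)), so a saturated ring at this carbon does not by itself set the number and the identity of the ring matters even at an equal heavy-atom count. No supporting data are available to explain this gain.

The step from compound 2 to compound 3 enlarges the ring and removes the oxygen in one change, so the compounds shown leave open which of the two carries the step; a plain piperidin-1-yl ring and a seven-membered azepane ring would separate them. Also open, on these data alone, is whether a ring is needed at all at this carbon, a question that an open-chain dipropylamino group would address.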